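Shortening the ether chain toward a direct phenoxy link

This account rests on a few compounds, and the source may have more. Where it says the series, first, only, none or still open, it means among the compounds named here.

The shared core carries an acid on one ring, an amide in the middle, and an ether on the far ring. Compound 1 `O=C(O)c1cccc(NC(=O)c2ccc(OCCCCc3ccccc3)cc2)c1` has a four-carbon chain ending in a phenyl between the oxygen and the ring; in an assay on HeLa cells for agonist activity at Bile acid receptor (Homo sapiens), read by a luciferase reporter (on this read-out lower numbers stand for an effect already at smaller amounts and higher numbers for an effect only at larger amounts of compound), compound 1 gives 26 nM. Compound 2 `O=C(O)c1cccc(NC(=O)c2ccc(OCc3ccccc3)cc2)c1` keeps only one carbon in that chain, and in this assay compound 2 gives 9.1 nM. The step of a 2.9-fold lower number from compound 1 to compound 2 (0.46 log units; beyond the scatter) is the only one recorded, so compound 2 stands at the lowest of the two numbers.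

Compound 3 `O=C(O)c1cccc(NC(=O)c2ccc(Oc3ccccc3)cc2)c1` removes that last carbon: phenyl in place of benzyl on an oxygen on an aromatic ring. Within the data shown here, only the step from compound 1 to compound 2 bears on this, and it pointed downward as the chain got shorter. A further step in the same direction, or none beyond the scatter, is expected; the estimated step is a 1.3-fold lower number from compound 2 to compound 3 (0.11 log units; within the scatter). Compound 3 is therefore estimated at 7 nM, within a range from 2.5 nM to 20 nM.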

Compound 3, half-maximal effective concentration: 10 nM
Compound 3: the middle estimate sits 1.4-fold (0.15 log units) below what was measured, within the range that was stated.
By their numbers in this assay, from the lowest: compounds 2 and 3 (each within the scatter of the next); then compound 1.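

Going from benzyloxy to phenoxy gives a 1.1-fold higher number from compound 2 to compound 3 (0.04 log units; within the scatter) in this assay, so taking away the last carbon on this oxygen leaves the read-out unchanged within the usual scatter. The earlier step, a 2.9-fold lower number from compound 1 to compound 2 (0.46 log units; beyond the scatter), lay beyond the scatter, so at this position the long chain and the benzyl group can be told apart, while benzyl and phenyl cannot. Nothing available explains why the two shortenings differ in this way.

A two-carbon chain ending in phenyl on this oxygen could help show how much chain length the read-out tolerates before the number climbs. An amine in place of the ether oxygen, or a fluorine on the far phenyl, would test other parts of this end of the molecule.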